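A few compounds are considered here, and "the series" means these few. Any claim that something is new, unique, unknown or untested is made for them only; others in the source may bear on it.

Compound 1 `O=C(Nc1ccccc1)c1cccc(/C=C2\CC(=O)N(c3ccccc3)C2=O)c1` gives > 100000 nM in an ADME assay on SW480 cells (Homo sapiens) for cytotoxicity, read by MTT assay, with a stated time of 72 h (on this read-out higher numbers stand for weaker inhibition and lower numbers for stronger inhibition), a limit of the assay and not a number.
Compound 2 `O=C(Nc1ccc(Cl)cc1)c1cccc(/C=C2\CC(=O)N(Cc3ccccc3)C2=O)c1` gives > 100000 nM in this assay, again a limit.
Compound 3 `Cc1ccc(N2C(=O)C/C(=C\c3cccc(C(=O)Nc4ccc(Cl)cc4)c3)C2=O)cc1` gives > 100000 nM in this assay, again a limit.

Compound 1 therefore stands at the limit, where all three measured compounds sit (the limit of > 100000 nM in this assay, at which 3 of the 3 values shown sit). Among the measured compounds shown here, the single measured step, a step that the two limits leave unreadable from compound 2 to compound 3, is left unreadable by the two limits, so no size of change has been observed in this assay at all. Compound 4 `O=C(c1cccc(/C=C2\CC(=O)N(c3ccccc3)C2=O)c1)N1CCCC1` differs from compound 1 in one place: pyrrolidin-1-yl in place of anilino on a carbonyl carbon. For the measured compounds named here, no measured step bears on this change. Compound 4 is expected to sit at the limit as well, since compound 1 gives > 100000 nM. The step of a number no higher from compound 1 to compound 4 (the limit leaves the size open) is expected to be none beyond the scatter. Compound 4 is estimated at 100000 nM, between 40000 nM and 300000 nM.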

Compound 4, half-maximal inhibitory concentration: > 100000 nM
Compound 4: no number, only a limit; the forecaster's own chance of this, stated with the estimate: 85%; the middle value lies on the limit itself.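

Compound 4 gives > 100000 nM in this assay, which is a limit. Among the compounds shown here, with compound 1 also at a limit, no step between compound 1 and compound 4 can be read. The compounds shown leave open which change would give a measurable value: the limit of > 100000 nM in this assay, at which 4 of the 4 values shown sit.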